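The source may hold more compounds than are shown below. What is called first, only, known or untested is meant among the compounds shown, and "the series" means these compounds.

Of the compounds shown here, two have so far been measured in a functional assay on A549 cells (Homo sapiens) for antiproliferative activity, read by MTT assay; on this read-out lower numbers stand for stronger inhibition and higher numbers for weaker inhibition. Compound 1 (`COc1ccc(-c2ccnc(Nc3ccc([N+](=O)[O-])cc3)n2)cc1`) gives 2730 nM, and compound 2 (`Clc1ccc(Nc2nccc(-c3ccc(Br)cc3)n2)cc1`) gives 6110 nM. Compound 2 therefore holds the higher number of the two, which means the weaker inhibition, and its gap to compound 1 lies beyond the usual scatter of repeated measurements.

Still unmeasured is compound 3 (`COc1ccc(-c2ccnc(Nc3ccc(Cl)cc3)n2)cc1`), which carries methoxy in place of bromo on an aromatic carbon, para to a large group: methoxy in place of bromo on an aromatic carbon. Among the measured compounds shown here, no pair of measured compounds differs in one place only, so there is no direct precedent for this change, and the expectation rests on little. Methoxy also occurs in compound 1, which stands at 2730 nM, and this is the only hint of direction. A modest move toward a lower number in this assay is therefore expected, probably not beyond the scatter: the estimated step is a 1.5-fold lower number from compound 2 to compound 3 (0.18 log units; within the scatter). For compound 3 the estimated value is 4000 nM, with an expected range from 1500 nM to 10000 nM.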

Compound 3, half-maximal inhibitory concentration: 20900 nM
For compound 3 the middle estimate is 5.2-fold (0.72 log units) below the measured one, and the stated range ends below it.
By their numbers in this assay, from the lowest: compound 1; then compound 2; then compound 3.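

In this assay, putting methoxy in place of bromo on an aromatic carbon, para to a large group, costs activity, with a 3.4-fold higher number from compound 2 to compound 3 (0.53 log units; beyond the scatter), and the second single-place comparison, chloro in place of nitro on an aromatic carbon, points the same way, with a 7.7-fold higher number from compound 1 to compound 3 (0.88 log units; beyond the scatter). Both steps lie beyond the scatter, which makes compound 3 the weakest of the three, and as compound 3 carries the same methoxy as compound 1, methoxy alone does not secure a low number in this series: here it comes with the weakest inhibition when chloro is its partner and with the stronger inhibition when nitro is. Nothing shown here accounts for either step.

On these data alone, whether the methoxy-for-bromo step would keep its direction or size with nitro in place of chloro remains open. As far as these compounds go, it is also open how an amine, a carboxylic acid or a longer chain such as ethoxy would compare with bromo and methoxy at this position.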